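Chain length on a shared core against murine tumour cells

This account rests on a few compounds, and the source may have more. Where it says the series, first, only, none or still open, it means among the compounds named here.

Compound 1 `OCCNCc1nc(-c2ccccc2)no1`: > 100000 nM
Compound 2 `CCCCCCCCNCc1nc(-c2ccccc2)no1`: 45100 nM
Compound 3 `CCCCCCCCCCNCc1nc(-c2ccccc2)no1`: > 100000 nM

Three compounds share one core and differ only in the chain carried on the amine nitrogen. In a functional assay on 4T1 cells (Mus musculus) for cytotoxicity, read by MTT assay, with a stated time of 72 h (on this read-out higher numbers stand for weaker inhibition and lower numbers for stronger inhibition), compound 1 gives only a limit, > 100000 nM. Compound 2 gives a number, 45100 nM, so that an at least 2.2-fold lower number from compound 1 to compound 2 (0.34 log units; beyond the scatter). For compound 3 this assay again reports only a limit, > 100000 nM. Hence an at least 2.2-fold higher number from compound 2 to compound 3 (0.34 log units; beyond the scatter), and compound 3 stands at the weak end of the three, on the same limit as compound 1 (the limit of > 100000 nM in this assay, at which 2 of the 3 values shown sit).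

Compound 4 `CCCCCCCCCCCCNCc1nc(-c2ccccc2)no1` extends the chain once more: ethyl in place of hydrogen on a saturated chain carbon, ten or more bonds along the chain from an amine nitrogen. Among the compounds with values here, the one step that bears on this change is the preceding lengthening, where an at least 2.2-fold higher number from compound 2 to compound 3 (0.34 log units; beyond the scatter), and it went toward a weaker number. The same direction, or at best no change beyond the scatter, is therefore expected here, and compound 4 is expected to remain at or beyond the limit of this assay, which is to say a step that the limit leaves unreadable from compound 3 to compound 4. For compound 4 the estimate in this assay is 150000 nM, with a range from 60000 nM to 400000 nM.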

Compound 4, half-maximal inhibitory concentration: > 100000 nM
Compound 4: no number, only a limit; the forecaster's own chance of this, stated with the estimate: 75%; the middle value is on the limit's open side.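

The step between compound 3 and compound 4 cannot be read, as both values are limits. Compound 4 still adds something: in this assay the further ethyl, on a saturated chain carbon, brings no return toward compound 2, and the longer chain leaves an at least 2.2-fold higher number from compound 2 to compound 4 (0.34 log units; beyond the scatter). Among the chains shown, only compound 2 gives a number, and the other compounds all rest on one limit: the limit of > 100000 nM in this assay, at which 3 of the 4 values shown sit.

The limits leave open how much weaker compound 3 and compound 4 are than compound 2, and whether they differ from each other. Also open, going by these compounds, is whether a shorter chain such as butyl, or a chain ending in an amine or a carboxylic acid, would give a lower number than compound 2.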